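Methoxybenzyl for phenyl on the piperazine nitrogen

The source may hold more compounds than are shown below. What is called first, only, known or untested is meant among the compounds shown, and "the series" means these compounds.

Of the compounds shown here, three built on the same core have been measured so far. Compound 1 `Cn1c(-c2ccc(NC(=O)CCl)cc2)nc(-c2ccccc2)c1-c1ccccc1` gives 28.7 ug/mL in a functional assay on HT-29 cells (Homo sapiens) for cytotoxicity, read by MTT assay, with a stated time of 24 h; on this read-out lower numbers stand for stronger inhibition and higher numbers for weaker inhibition. Compound 2 `Cn1cnnc1SCC(=O)Nc1ccc(-c2nc(-c3ccccc3)c(-c3ccccc3)n2C)cc1` gives 10.7 ug/mL in this assay, and compound 3 `Cn1c(-c2ccc(NC(=O)CN3CCN(c4ccccc4)CC3)cc2)nc(-c2ccccc2)c1-c1ccccc1` gives 8.6 ug/mL in this assay. The steps between them are a 2.7-fold lower number from compound 1 to compound 2 (0.43 log units; beyond the scatter) and a 3.3-fold lower number from compound 1 to compound 3 (0.52 log units; beyond the scatter), whereas a 1.2-fold lower number from compound 2 to compound 3 (0.09 log units; within the scatter). Compound 3 thus holds the lowest number of the three, but its gap to compound 2 lies within the scatter, so only its separation from compound 1 is beyond it.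

Compound 4 `COc1ccc(CN2CCN(CC(=O)Nc3ccc(-c4nc(-c5ccccc5)c(-c5ccccc5)n4C)cc3)CC2)cc1` differs from compound 3 in one place: 4-methoxybenzyl in place of phenyl on an amine nitrogen in a ring. Within the data shown here, no measured step touches this position; all three concern the group on the saturated chain carbon bound to the carbonyl carbon. The only indirect bearing is the gap a 1.2-fold lower number from compound 2 to compound 3 (0.09 log units; within the scatter), which shows that two quite different groups at that end of the molecule gave numbers within the scatter of each other. On this basis no step beyond the scatter is expected in this assay in either direction. Compound 4 is therefore estimated at 9 ug/mL, with a range from 4 ug/mL to 20 ug/mL. That corresponds to an expected 1.0-fold higher number from compound 3 to compound 4 (0.02 log units; within the scatter).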

Compound 4, half-maximal inhibitory concentration: 77.3 ug/mL
Beside the measured number, compound 4's estimate is 8.6-fold (0.93 log units) below it; the whole stated range lies below it.
By their numbers in this assay, from the lowest: compounds 3 and 2 (each within the scatter of the next); then compound 1; then compound 4.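

The phenyl on the amine nitrogen in the ring turns out not to be a free place to change: in this assay the swap to 4-methoxybenzyl gives a 9.0-fold higher number from compound 3 to compound 4 (0.95 log units; beyond the scatter). Among these compounds, all the earlier steps concerned the group on the saturated chain carbon bound to the carbonyl carbon, and none of them showed what the far end of that group contributes; this step shows that a change there alone can move the number beyond the scatter, and towards weaker inhibition. The change is large enough to carry the number past that of compound 1: compound 1 gives 28.7 ug/mL and compound 4 gives 77.3 ug/mL, so here the large ring-bearing group no longer gives the lower number that it gives in compound 3. The compounds carry no measurement that would explain this rise.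

The step changes several things at once, adding both a carbon link to the ring and a methoxy group, so it cannot say which of them accounts for the weaker inhibition. Plain benzyl and 4-methoxyphenyl on the same nitrogen would separate the two, and a small methyl there would show how much of an aromatic ring this position needs at all.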